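A few compounds are considered here, and "the series" means these few. Any claim that something is new, unique, unknown or untested is made for them only; others in the source may bear on it.

Measured in a functional assay on NCI-H520 cells (Homo sapiens) for inhibition, read by MTT assay, with a stated time of 48 h, tested at 10 uM; a higher number here means more inhibition at the concentration tested (going by the name of the read-out), a lower number less inhibition:
- compound 1, `COc1ccc(F)cc1Nc1cc(NC(=O)Nc2c(Cl)cccc2Cl)ncn1`: 38.1%
- compound 2, `COc1ccc(Br)cc1Nc1cc(NC(=O)Nc2c(Cl)cccc2Cl)ncn1`: 45%
- compound 3, `COc1ccc(C(F)(F)F)cc1Nc1cc(NC(=O)Nc2c(Cl)cccc2Cl)ncn1`: 33%

Compound 3 stands lowest of the three numbers in this assay. Its nearest neighbour is compound 1, and the step of a number 5.1 percentage points lower from compound 1 to compound 3 (within the scatter) lies within the scatter, so these two cannot be told apart. Its furthest neighbour is compound 2, and the step of a number 12 percentage points lower from compound 2 to compound 3 (beyond the scatter) is beyond the scatter, though only modest.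

Compound 4, `COc1ccc(OC)c(Nc2cc(NC(=O)Nc3c(Cl)cccc3Cl)ncn2)c1`, differs from compound 3 in one place: methoxy in place of trifluoromethyl on an aromatic carbon. Going by the values given here, no measured step introduces a methoxy group at this place, so the only guide is how much the numbers moved when the group at this position was exchanged among fluoro, bromo and trifluoromethyl: a number 6.9 percentage points higher from compound 1 to compound 2 (within the scatter), a number 5.1 percentage points lower from compound 1 to compound 3 (within the scatter) and a number 12 percentage points lower from compound 2 to compound 3 (beyond the scatter). All three exchanges stayed small, so for compound 4 the expected step is likewise small, a number 5 percentage points higher from compound 3 to compound 4 (within the scatter), and may not exceed the scatter. Compound 4 is therefore estimated at 38% in this assay, with a range from 24% to 52%.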

Compound 4, a percentage reported as inhibition, at one concentration (the size of the read-out at that concentration, not a potency): 74%
Compound 4: middle estimate off by 36 percentage points, on the low side; measured number above the stated range.
By their numbers in this assay, from the lowest: compounds 3, 1 and 2 (each within the scatter of the next, the first and the last beyond it); then compound 4.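

In this assay this position proves far more sensitive than the exchanges among fluoro, bromo and trifluoromethyl suggested: methoxy gives a number 41 percentage points higher from compound 3 to compound 4 (beyond the scatter) and a number 35.9 percentage points higher from compound 1 to compound 4 (beyond the scatter) and a number 29 percentage points higher from compound 2 to compound 4 (beyond the scatter), all three beyond the scatter. The rise appears whichever of the three earlier groups methoxy replaces, so in this small set compound 4 stands apart from the others, with the new methoxy para to a methoxy group. The data shown contain no measurement that explains why this one exchange moves the number so much.

On these data alone, it remains open whether the rise is confined to methoxy or would also appear with a longer chain on the oxygen, such as ethoxy, or with a hydroxyl or an amine on this carbon. A reading at one concentration also leaves the actual potency of compound 4 open.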